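This account rests on a few compounds, and the source may have more. Where it says the series, first, only, none or still open, it means among the compounds named here.

Working notes on the series. In a functional assay on MCF7 cells (Homo sapiens) for inhibition, read by fluorescence, with a stated time of 72 h (on this read-out higher numbers stand for weaker inhibition and lower numbers for stronger inhibition), compound 1 `CC(C)Cn1cnc2c(NC(=N)N)nc(N)nc21` gives 96600 nM. Within the data shown here, compound 2 `CC(C)n1cnc2c(NC(=N)N)nc(NCCO)nc21` gives 12400 nM in this assay, the lower of the two numbers so far, and the difference to compound 1 lies beyond the scatter. Compound 3 `CC(C)n1cnc2c(NC(=N)N)nc(N3CCC[C@@H]3CO)nc21` has not yet been measured; it differs from compound 2 by 2-(hydroxymethyl)pyrrolidin-1-yl in place of (2-hydroxyethyl)amino on an aromatic carbon. Among the measured compounds shown here, no measured pair shows this change, so the expectation rests on compound 2 alone. The step from compound 2 to compound 3 in this assay is expected to be small, a 1.4-fold lower number from compound 2 to compound 3 (0.14 log units; within the scatter), not clearly beyond the scatter. Compound 3 is estimated at 9000 nM, with a range of 2500 nM to 30000 nM.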

Compound 3, half-maximal inhibitory concentration: 20400 nM
The estimate for compound 3 lay 2.3-fold (0.36 log units) below the measured number; measured number inside the range.
By their numbers in this assay, from the lowest: compounds 2 and 3 (each within the scatter of the next); then compound 1.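

In this assay, the step of a 1.6-fold higher number from compound 2 to compound 3 (0.22 log units; within the scatter) comes with 2-(hydroxymethyl)pyrrolidin-1-yl in place of (2-hydroxyethyl)amino on the aromatic carbon between two ring nitrogen atoms. At this position, then, a five-membered non-aromatic ring carrying a defined stereocentre can replace the open chain with no step beyond the scatter. No available evidence bears on this result. Still open, from the compounds shown here alone, is whether the opposite stereoisomer, an unsubstituted pyrrolidin-1-yl or a carboxylic acid on the ring would differ from compound 3 beyond the scatter.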